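Remote aryl swaps and the acid dissociation constant

The source may hold more compounds than are shown below. What is called first, only, known or untested is meant among the compounds shown, and "the series" means these compounds.

Measured so far:
compound 1 `COc1cccc(CNCCCNc2ccnc3cc(Cc4cc(C)cc(C)c4)ccc23)c1O`: 9.47
compound 2 `COc1cccc(CNCCCNc2ccnc3cc(Cc4ccc(F)cc4)ccc23)c1O`: 9.47
compound 3 `COc1cccc(CNCCCNc2ccnc3cc(Cc4cccc(C(F)(F)F)c4)ccc23)c1O`: 9.47

In a physicochemical assay for acid dissociation, compound 3 sits level with compounds 1 and 2 at the digits shown. The steps among the three, no change at the digits printed from compound 1 to compound 2 (within the scatter), no change at the digits printed from compound 1 to compound 3 (within the scatter) and no change at the digits printed from compound 2 to compound 3 (within the scatter), are all within the scatter, so exchanging the aryl group on the saturated chain carbon has left this read-out untouched across these compounds. Compound 4 `COc1ccccc1Oc1ccc2c(NCCCNCc3cccc(OC)c3O)ccnc2c1` differs from compound 3 in 2-methoxyphenoxy in place of 3-(trifluoromethyl)benzyl on an aromatic carbon. The group that changes is again the one remote from the shared core's chain amines, so no step beyond the scatter is expected in this assay. Compound 4 is therefore estimated at 9.47, range 9.17 to 9.77, an expected step of no change at the digits printed from compound 3 to compound 4 (within the scatter).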

Compound 4, acid dissociation constant: 9.28
For compound 4 the middle estimate is 0.19 log units above the measured one; measured number inside the range.
By their numbers in this assay, from the lowest: compounds 4, 1, 2 and 3 (each within the scatter of the next).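

Swapping a benzyl group for an oxygen-linked aryl group at this aromatic carbon, not just exchanging one benzyl group for another, stays within the scatter in this assay: a number 0.19 log units lower from compound 3 to compound 4 (within the scatter), a number 0.19 log units lower from compound 2 to compound 4 (within the scatter) and a number 0.19 log units lower from compound 1 to compound 4 (within the scatter). This holds although 2-methoxyphenoxy brings 2 hydrogen-bond acceptors where each benzyl group has 0. No supporting measurement bears on this result.

Open, as far as these compounds go, is whether an amine or a carboxylic acid at this aromatic carbon would give a step beyond the scatter. Also open, from the compounds shown here alone, is how a longer chain in the shared core would read.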